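Cytotoxicity of a substituted purine series toward lymphoblast cells

The source may report more compounds than this note shows. Statements on the series, on what has been measured and on what is new or still open speak of the compounds shown alone.

The series shares a purine-like core carrying a methylenecyclopropane bearing two hydroxymethyl groups, and differs only in the group on one aromatic carbon. Compound 1 `CC(C)CSc1nc(N)nc2c1ncn2/C=C1/CC1(CO)CO` carries an isobutylsulfanyl group there; in an ADME assay on CCRF-HSB-2 cells (Homo sapiens) for cytotoxicity, with a stated time of 7 days (a lower number here means that less compound is tolerated, a higher number that more compound is tolerated), compound 1 gives 60000 nM. Compound 2 `CCCNc1nc(N)nc2c1ncn2/C=C1/CC1(CO)CO` carries a propylamino group instead. In this assay compound 2 reaches only the limit of the assay, > 20000 nM. Compound 3 `CCCCCOc1nc(N)nc2c1ncn2/C=C1/CC1(CO)CO` carries a pentyloxy group. In this assay compound 3 likewise reaches only the limit, > 20000 nM. Compound 3 therefore stands at the limit together with one other member of the set, as recorded by the limit of > 20000 nM in this assay, at which 2 of the 3 values shown sit, and no number places it above or below its neighbours. The steps a step that the limit leaves unreadable from compound 1 to compound 2, a step that the limit leaves unreadable from compound 1 to compound 3 and a step that the two limits leave unreadable from compound 2 to compound 3 are all unreadable for the same reason.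

Compound 4 `COCCOc1nc(N)nc2c1ncn2/C=C1/CC1(CO)CO` differs from compound 3 by methoxy in place of propyl on a saturated chain carbon, two bonds along the chain from an oxygen on an aromatic ring. Among the compounds with values here, no measured step bears on such a change, and every readable or unreadable value in the set lies at or beyond the limit, so the step that the limit leaves unreadable from compound 3 to compound 4 is expected to stay within the scatter. Compound 4 is estimated at 50000 nM in this assay, within 20000 nM to 150000 nM, most likely reported as a limit.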

Compound 4, half-maximal cytotoxic concentration: > 20000 nM
Compound 4: no number, only a limit; the forecaster's own chance of this, stated with the estimate: 70%; the middle value is on the limit's open side.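

In this assay compound 4 gives > 20000 nM as a limit only. Within the data shown here, no step between compound 4 and compound 1, compound 2 or compound 3 can be read, and the values offer little to compare: the limit of > 20000 nM in this assay, at which 3 of the 4 values shown sit. The compounds shown leave open whether the groups on this aromatic carbon differ at all in how much compound the cells tolerate.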